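The source may hold more compounds than are shown below. What is called first, only, known or untested is meant among the compounds shown, and "the series" means these compounds.

Measured so far in a functional assay on A549 cells (Homo sapiens) for cytotoxicity, read by resazurin assay, with a stated time of 72 h; on this read-out lower numbers stand for stronger inhibition and higher numbers for weaker inhibition:

Compound 1 `O=C(/C=C/c1ccc(OCCCCCCO[N+](=O)[O-])c(O)c1)OCCCCCCO[N+](=O)[O-]` gives > 50000 nM, which is a limit of the assay.
Compound 2 `COc1cc(/C=C/C(=O)OCCCCCO[N+](=O)[O-])ccc1O` gives 6390 nM.
Compound 3 `COc1cc(/C=C/C(=O)OCCCCO[N+](=O)[O-])ccc1OCCCCO[N+](=O)[O-]` gives > 50000 nM, which is a limit of the assay.

Compound 1 stands at the limit of > 50000 nM in this assay, at which 2 of the 3 values shown sit; only a limit is known for it, and one of the other two values shown is a limit as well. Compound 2 is the only one of the three with a number in this assay. Among the measured compounds shown here, no step between measured compounds differing in one place has been counted, so no measured change sets a scale for this series.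

Compound 4 `COc1cc(/C=C/C(=O)OCCCCCCO[N+](=O)[O-])ccc1OCCCCCCO[N+](=O)[O-]` is the next to be measured in this assay. It differs from compound 1 by methyl in place of hydrogen on an oxygen on an aromatic ring. Compound 3 carries the methoxy group that this change introduces, and in this assay compound 3 gives > 50000 nM, a limit. With compound 1 itself at a limit, no shift beyond the scatter is expected, and the outcome is most likely another limit. Compound 4 is expected at 60000 nM, within 20000 nM to 150000 nM, which means an expected step that the limit leaves unreadable from compound 1 to compound 4.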

Compound 4, half-maximal inhibitory concentration: > 50000 nM
Compound 4: only a limit was reported (the forecaster's own chance of this, stated with the estimate: 80%); the middle value is on the limit's open side.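

No step can be read from compound 1 to compound 4, because both compounds sit at a limit of the assay: the limit of > 50000 nM in this assay, at which 3 of the 4 values shown sit.

As far as these compounds go, what hydroxy to methoxy does at this position remains open, as neither compound 1 nor compound 4 has a numerical value.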